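This account rests on a few compounds, and the source may have more. Where it says the series, first, only, none or still open, it means among the compounds named here.

Measured in a functional assay on NCI-H460 cells (Homo sapiens) for antiproliferative activity, read by CCK-8 assay, with a stated time of 72 h, tested at 8 uM; on this read-out higher numbers stand for a stronger effect at the one concentration tested and lower numbers for a weaker effect:
compound 1 `CCC(C)n1cnc2c(NCc3ccc(C(=O)Nc4ccccc4N)cc3)nc(Cl)nc21` gives 67.7%
compound 2 `CCCCn1cnc2c(NCc3ccc(C(=O)Nc4ccccc4N)cc3)nc(Cl)nc21` gives 23.7%

Of these two numbers, compound 2 holds the lower one, and the gap to compound 1 is beyond the scatter: a number 44 percentage points lower from compound 1 to compound 2 (beyond the scatter). The unmeasured compound 3 `Nc1ccccc1NC(=O)c1ccc(CNc2nc(Cl)nc3c2ncn3C2CCCC2)cc1` differs from compound 2 in one place: cyclopentyl in place of butyl on an aromatic nitrogen. Among the compounds with values here, the only measured step that touches this same position is the one from compound 1 to compound 2, where butyl replaced sec-butyl and the number fell by a large amount. Within the data shown here, that step shows that the group on this ring nitrogen can matter a great deal, but no measured compound here carries cyclopentyl, so the direction for compound 3 rests on little. Compound 3 is expected to land around 50% in this assay, with a plausible range from 20% to 80%. This estimate corresponds to an expected change a number 26.3 percentage points higher from compound 2 to compound 3 (beyond the scatter), leaning upward but uncertain.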

Compound 3, a percentage reported as inhibition, at one concentration (the size of the read-out at that concentration, not a potency): 57.4%
Beside the measured number, compound 3's estimate is 7.4 percentage points below it; the measured number falls inside the stated range.
By their numbers in this assay, from the lowest: compound 2; then compound 3; then compound 1.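

In this assay, the change to cyclopentyl on the aromatic nitrogen gives a number 33.7 percentage points higher from compound 2 to compound 3 (beyond the scatter), so the low number of compound 2 does not hold for every group at this position, and a ring of carbon only can restore much of what butyl lost. Cyclopentyl does not fully match sec-butyl, however, with a number 10.3 percentage points lower from compound 1 to compound 3 (beyond the scatter), a modest step, so among these three compounds butyl sits far below the other two, while those two stand much closer together. No evidence is available to explain why these groups differ.

From the compounds shown here alone, whether cyclohexyl or isopropyl on this nitrogen would fall near compound 1 or near compound 2 remains open. So does the effect of an amine on the cyclopentyl ring.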